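The compounds below may be only part of what the source reports. "The series", "measured", "known", "first", "only" and "open" are said of these compounds alone.

Measured so far:
compound 1 `C=C1[C@@H](OC(C)=O)C[C@@H]2[C@](C)(CO[Si](C)(C)C(C)(C)C)[C@H](OC(C)=O)CC[C@@]2(C)[C@@H]1C[C@@H](Nc1ccc(Br)cc1)C1=CCOC1=O` gives 3920 nM
compound 2 `C=C1[C@@H](OC(C)=O)C[C@@H]2[C@](C)(COC=O)[C@H](OC(C)=O)CC[C@@]2(C)[C@@H]1C[C@@H](Nc1ccccc1C(=O)O)C1=CCOC1=O` gives 30800 nM
compound 3 `C=C1[C@@H](OC(C)=O)C[C@@H]2[C@](C)(COC=O)[C@H](OC(C)=O)CC[C@@]2(C)[C@@H]1C[C@@H](Nc1ccccc1F)C1=CCOC1=O` gives 16400 nM

All three values come from a functional assay on MCF7 cells (Homo sapiens) for cytotoxicity, read by sulforhodamine B assay (on this read-out higher numbers stand for weaker inhibition and lower numbers for stronger inhibition), and compound 1 has the lowest number, beyond the scatter against both others. Next in the series is compound 4 `C=C1[C@@H](OC(C)=O)C[C@@H]2[C@](C)(CO[Si](C)(C)C(C)(C)C)[C@H](OC(C)=O)CC[C@@]2(C)[C@@H]1C[C@@H](Nc1cccc(F)c1)C1=CCOC1=O`, which differs from compound 1 as follows (3-fluorophenyl in place of 4-bromophenyl on an amine nitrogen) with 3-fluorophenyl in place of 4-bromophenyl on an amine nitrogen. For the measured compounds named here, the one measured step that touches an aromatic substituent (a 1.9-fold lower number from compound 2 to compound 3 (0.27 log units; within the scatter)) stayed within the scatter, but it is a different exchange, so it is weak guidance. Going by the values given here, no measured step removes a 4-bromophenyl group. No step beyond the scatter is therefore expected in this assay, with a slightly higher number the likelier direction. The estimate for compound 4 is 5000 nM (range 2000 nM to 13000 nM). The expected change is (a 1.3-fold higher number from compound 1 to compound 4 (0.11 log units; within the scatter)) small.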

Compound 4, half-maximal inhibitory concentration: 3820 nM
For compound 4 the middle estimate is 1.3-fold (0.12 log units) above the measured one; measured number inside the range.
By their numbers in this assay, from the lowest: compounds 4 and 1 (each within the scatter of the next); then compounds 3 and 2 (each within the scatter of the next).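

In this assay, 3-fluorophenyl in place of 4-bromophenyl on an amine nitrogen gives a 1.0-fold lower number from compound 1 to compound 4 (0.01 log units; within the scatter). For the compounds shown here, this is the first readable exchange at this position with the silyl ether kept in place, and it shows that the two aryl groups cannot be told apart on this read-out. Nothing at hand bears on why this is so.

Still open, from the compounds shown here alone, is whether a pyridine ring or a plain alkyl chain on the amine nitrogen would give a number in the same range. Also open, going by these compounds, is whether the same aryl exchange reads alike with the formate ester of compound 2 and compound 3 in place of the silyl ether.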